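The source may hold more compounds than are shown below. What is called first, only, known or untested is meant among the compounds shown, and "the series" means these compounds.

Measured compounds in an assay on isolated protein for inhibition of Melanocyte-stimulating hormone receptor (Mus musculus); a lower number here means a stronger inhibitor, a higher number a weaker inhibitor:
- compound 1, `CS(=O)(=O)N(CC1CC1)c1ccccc1N1CCN(C(=O)[C@H](CC(=O)N2CCNCC2)Cc2ccc(Cl)cc2)CC1`: > 8000 nM, a limit of the assay
- compound 2, `CC(=O)N1CCN(C(=O)C[C@H](Cc2ccc(Cl)cc2)C(=O)N2CCN(c3ccccc3N(CC3CC3)S(C)(=O)=O)CC2)CC1`: > 10000 nM, a limit of the assay

Compound 1 and compound 2 differ at one place, acetyl in place of hydrogen on an amine nitrogen in a ring, and the step that the two limits leave unreadable from compound 1 to compound 2 is left unreadable because both ends are limits, see the limit of > 10000 nM in this assay, at which 1 of the 2 values shown sits, and (the limit of > 8000 nM in this assay, at which 1 of the 2 values shown sits). Compound 2 therefore stands only at a limit in this assay, with no number behind it.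

Compound 3, `CC(C)(C)CC(=O)N1CCN(C(=O)C[C@H](Cc2ccc(Cl)cc2)C(=O)N2CCN(c3ccccc3N(CC3CC3)S(C)(=O)=O)CC2)CC1`, takes the change tert-butyl in place of hydrogen on a saturated chain carbon bound to a carbonyl carbon, so the acetyl of compound 2 becomes neopentylcarbonyl. Within the data shown here, no measured step of readable size bears on this change, and no direction can be read from it. For compound 3 the expectation is that this assay again reports only a limit, with an estimated step that the limit leaves unreadable from compound 2 to compound 3 from compound 2 that is not readable against the scatter. The estimate for compound 3 in this assay is 15000 nM, within 4000 nM to 60000 nM.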

Compound 3, half-maximal inhibitory concentration: > 1800 nM
Compound 3: no number, only a limit (the forecaster's own chance of this, stated with the estimate: 85%); the middle value is on the limit's open side.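

In this assay compound 3 gives > 1800 nM, a limit of the assay. The steps from compound 1 and compound 2 to compound 3 cannot be read: all three compounds stand only at limits. Still open, on these data alone, is whether neopentylcarbonyl in place of acetyl shifts inhibition at all.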